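A few compounds are considered here, and "the series" means these few. Any claim that something is new, unique, unknown or untested is made for them only; others in the source may bear on it.

Measured so far:
compound 1 `Oc1ccccc1-c1cc(-c2ccc(F)cc2)cc(-c2ccccc2O)n1` — > 50000 nM
compound 2 `Oc1ccc(-c2cc(-c3ccccc3F)cc(-c3ccccc3O)n2)cc1` — > 50000 nM

In a functional assay on HCT-15 cells (Homo sapiens) for inhibition (on this read-out lower numbers stand for stronger inhibition and higher numbers for weaker inhibition), compound 1 gives only a limit of the assay, > 50000 nM. Compound 2 likewise gives only a limit in this assay, > 50000 nM. Both values sit at the limit of > 50000 nM in this assay, at which 2 of the 2 values shown sit, so no number places compound 2 within the set. Compound 3 `Oc1ccc(-c2cc(-c3ccc(F)cc3)cc(-c3ccccc3O)n2)cc1` is not yet measured and differs from compound 2 by 4-fluorophenyl in place of 2-fluorophenyl on an aromatic carbon. Among the measured compounds shown here, no measured step covers this change. Compound 1, which already carries the 4-fluorophenyl group, shows > 50000 nM. Compound 3 is therefore expected to remain at the limit, estimated at 100000 nM with a range of 50000 nM to 300000 nM. The expected step that the limit leaves unreadable from compound 2 to compound 3 is none beyond the scatter.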

Compound 3, half-maximal inhibitory concentration: > 50000 nM
Compound 3 was reported as a limit (the forecaster's own chance of this, stated with the estimate: 85%); the middle value lies beyond the limit too.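

No step can be read among compound 1, compound 2 and compound 3, as each gives only a limit in this assay: the limit of > 50000 nM in this assay, at which 3 of the 3 values shown sit.

The compounds shown leave open which change to the shared core, if any, would give a measurable value in this assay.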